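The source may hold more compounds than are shown below. What is called first, only, known or untested is meant among the compounds shown, and "the series" means these compounds.

Measured so far:
compound 1, `Cc1cc(C(=O)O)nn1Cc1cc(Br)ccc1OCc1ccccc1`, 1.2
compound 2, `Cc1cc(C(=O)NCc2cccnc2)nn1Cc1cc(Cl)ccc1OCc1ccccc1`, > 3.7

In a physicochemical assay for lipophilicity, at pH 7.4 (a higher number here means a more lipophilic compound, a lower number a more polar compound), compound 1 gives 1.2. For compound 2 this assay returned only a limit, > 3.7, which is the limit of > 3.7 in this assay, at which 1 of the 2 values shown sits; how far past that limit compound 2 actually sits is not known. Among the compounds with values here, no pair of measured compounds differing in one place is available here, so nothing measured tells how a single structural change moves the distribution coefficient.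

Compound 3, `Cc1cc(NC(=O)c2c(F)cccc2F)nn1Cc1cc(Cl)ccc1OCc1ccccc1`, is not yet measured. It differs from compound 2 in one place: ((2,6-difluorophenyl)carbonyl)amino in place of ((pyridin-3-yl)methyl)carbamoyl on an aromatic carbon. Compound 3 is expected to sit at or past the limit that compound 2 reached, and the step that the limit leaves unreadable from compound 2 to compound 3 is expected to be modest and toward the more lipophilic side; since compound 2 is known only as a limit, a step within the scatter, or none at all, cannot be excluded. Compound 3 is estimated at 4.3, with a range from 3.7 to 5, and will most probably again be reported only as a limit rather than a number.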

Compound 3, distribution coefficient: > 3.7
Compound 3: a limit, no number; the forecaster's own chance of this, stated with the estimate: 85%; the middle value is on the limit's open side.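

In this assay compound 3 gives > 3.7, which is a limit and not a number. With compound 2 and compound 3 both reported as limits, no step between them can be read: the limit of > 3.7 in this assay, at which 2 of the 3 values shown sit.

Still open, going by these compounds, is where each of the two compounds actually sits, and how far ((2,6-difluorophenyl)carbonyl)amino in place of ((pyridin-3-yl)methyl)carbamoyl moves the distribution coefficient.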